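Aryl change on the shared core: outlook for compound 4

The compounds below may be only part of what the source reports. "The series", "measured", "known", "first", "only" and "open" are said of these compounds alone.

Three compounds share one core and differ only in the aryl group attached there: compound 1 `OC[C@H]1O[C@@H](n2cnc3c(NCc4ccc(Cl)cc4)ncnc32)[C@H](O)[C@@H]1O`, compound 2 `OC[C@H]1O[C@@H](n2cnc3c(NCc4ccc(Br)cc4)ncnc32)[C@H](O)[C@@H]1O` and compound 3 `OC[C@H]1O[C@@H](n2cnc3c(NCc4ccc(F)cc4Cl)ncnc32)[C@H](O)[C@@H]1O`. In a functional assay on K562 cells (Homo sapiens) for antiproliferative activity, with a stated time of 72 h (a lower number here means a stronger inhibitor, a higher number a weaker inhibitor), compound 1 gives 218000 nM, compound 2 gives 68200 nM and compound 3 gives 15600 nM. Compound 2 therefore holds the second highest of the three numbers: the step of a 3.2-fold lower number from compound 1 to compound 2 (0.50 log units; beyond the scatter) puts it below compound 1, while the step of a 4.4-fold lower number from compound 2 to compound 3 (0.64 log units; beyond the scatter) leaves it above compound 3. Across the whole set the step is a 14-fold lower number from compound 1 to compound 3 (1.15 log units; beyond the scatter).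

Compound 4 `Cc1cccc(CNc2ncnc3c2ncn3[C@@H]2O[C@H](CO)[C@@H](O)[C@H]2O)c1O` is not yet measured. It differs from compound 2 by 2-hydroxy-3-methylphenyl in place of 4-bromophenyl on a saturated chain carbon bound to a nitrogen on an aromatic ring.

Among the compounds with values here, two measured steps bear on this. The step of a 3.2-fold lower number from compound 1 to compound 2 (0.50 log units; beyond the scatter) is a halogen-for-halogen exchange and says little about a hydroxy and a methyl entering. The step of a 4.4-fold lower number from compound 2 to compound 3 (0.64 log units; beyond the scatter) shows that changing the substitution pattern of the phenyl can move the number beyond the scatter. Within the data shown here, no measured step replaces a halogen with an oxygen-bearing group, so the direction is open; a modest step in either direction seems as likely as none.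

The estimate for compound 4 in this assay is 60000 nM, with a range from 12000 nM to 300000 nM, meaning an expected step of a 1.1-fold lower number from compound 2 to compound 4 (0.06 log units; within the scatter).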

Compound 4, half-maximal inhibitory concentration: 18000 nM
Estimate against measurement, compound 4: 3.3-fold (0.52 log units) above; the measured number falls inside the stated range.
By their numbers in this assay, from the lowest: compounds 3 and 4 (each within the scatter of the next); then compound 2; then compound 1.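

In this assay the aryl group on a saturated chain carbon bound to a nitrogen on an aromatic ring needs no halogen to reach the lower numbers of this set: a 3.8-fold lower number from compound 2 to compound 4 (0.58 log units; beyond the scatter) is a step beyond the scatter in the same direction as the halogen changes, and a 12-fold lower number from compound 1 to compound 4 (1.08 log units; beyond the scatter) is large. With a 1.2-fold higher number from compound 3 to compound 4 (0.06 log units; within the scatter) as the remaining step, 2-hydroxy-3-methylphenyl and 2-chloro-4-fluorophenyl, which have no substituent in common, cannot be told apart in this assay, whereas the 4-chlorophenyl and 4-bromophenyl compounds both give higher numbers than either. This grouping rests on four compounds only, and no measurement shown here accounts for it.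

Within the data shown here, the single step to compound 4 brings in the hydroxy and the methyl together, so the share of each remains open; 2-hydroxyphenyl and 3-methylphenyl as separate groups would divide it. Also open, going by these compounds, is whether the hydroxy itself matters, which a methoxy or an amino group in its place, as in 2-methoxy-3-methylphenyl or 2-amino-3-methylphenyl, would address.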